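The source may report more compounds than this note shows. Statements on the series, on what has been measured and on what is new or still open speak of the compounds shown alone.

The measured compounds:
Compound 1, `CCOC(=O)C[n+]1cccc(O)c1`, in a functional assay on U-87MG ATCC cells for cytotoxicity against U-87 MG (Homo sapiens), read by MTT assay, with a stated time of 48 h (on this read-out lower numbers stand for stronger inhibition and higher numbers for weaker inhibition), gives only a limit of the assay, > 200000 nM.
Compound 2, `CCOC(=O)C[n+]1cccc2cc(O)ccc21`, likewise gives only a limit, > 200000 nM.
Compound 3, `O=C(O[C@H]1C[C@H](n2cc(F)c(=O)[nH]c2=O)O[C@@H]1COP(=O)(O)Oc1ccccc1)c1ccccc1`, gives 800 nM.

Compound 3 is thus the only one of the three with a measured number; the other two sit at the limit of > 200000 nM in this assay, at which 2 of the 3 values shown sit. Compound 4, `CCCCCCCCCc1ccc(OP(=O)(O)OC[C@H]2O[C@@H](n3cc(F)c(=O)[nH]c3=O)C[C@@H]2OC(=O)c2ccccc2)cc1`, has not yet been measured. It differs from compound 3 in one place: nonyl in place of hydrogen on an aromatic carbon. Among the measured compounds shown here, no step between measured compounds is available here, so this change has no precedent in these data. The expectation is a step of small size, within the scatter and with no confident direction, which is what the estimated step of a 1.3-fold lower number from compound 3 to compound 4 (0.12 log units; within the scatter) means. Compound 4 is therefore expected to give about 600 nM, estimated within a range from 150 nM to 2500 nM.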

Compound 4, half-maximal inhibitory concentration: 6730 nM
Estimate against measurement, compound 4: 11-fold (1.05 log units) below; measured number outside the range, above it.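

In this assay, nonyl in place of hydrogen on this aromatic carbon gives an 8.4-fold higher number from compound 3 to compound 4 (0.92 log units; beyond the scatter), so the position is sensitive to this change and a substituent here can weaken the read-out. Among the compounds shown here, this is the only step between measured compounds, so it is the first sign that this position matters at all. Nothing measured here explains the size of the step.

One step cannot show a trend with chain length. From the compounds shown here alone, whether a shorter chain such as methyl or butyl, or an amine or a carboxylic acid, in place of nonyl would give a smaller step remains open.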